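This account rests on a few compounds, and the source may have more. Where it says the series, first, only, none or still open, it means among the compounds named here.

In an ADME assay on cells (Erythrocyte, Homo sapiens), read by spectrophotometry and hemolysis, with a stated time of 24 h (a lower number here means a stronger inhibitor, a higher number a weaker inhibitor), compound 2 (`CC(=O)c1ccccc1OCc1ccc2no[n+]([O-])c2c1`) stands only at a limit. Compound 2 gives > 200 uM, which is a limit and not a number. Compound 1 (`O=Cc1ccccc1OCc1ccc2no[n+]([O-])c2c1`) is also known only by a limit, > 100 uM. Compound 3 (`CC(=O)c1ccccc1OCc1ccc2c(c1)=[N+]([O-])C(C)(C)[N+]=2[O-]`) likewise reports only a limit, < 50 uM.

Compound 4 (`C=CCNC(=S)N/N=C\c1ccccc1OCc1ccc2no[n+]([O-])c2c1`) keeps the core of compound 2 and carries this change on an aromatic carbon: a group of 9 heavy atoms (5 carbon, 3 nitrogen, 1 sulfur; no ring) in place of a group of 3 heavy atoms (2 carbon, 1 oxygen; no ring), on an aromatic carbon. The incoming group has no common name and takes the place of acetyl. Going by the values given here, the one measured step that bears on this site is a step that the two limits leave unreadable from compound 1 to compound 2, so it offers no size to carry over, and the expectation for the far larger change remains loose.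

Compound 2 gives > 200 uM, a limit, so the only move that could be read in this assay is toward lower numbers. The expected change is an at least 1.6-fold lower number from compound 2 to compound 4 (0.22 log units; that floor lies within the scatter), an estimate of uncertain size. For compound 4 the estimated value is 120 uM, with an expected range from 40 uM to 300 uM.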

Compound 4, concentration for 50% inhibition: 139 uM
Compound 4: middle estimate off by 1.2-fold (0.06 log units), on the low side; low and high end bracket the measured number.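

In this assay, going by these compounds alone, compound 4 gives 139 uM, the first value on this aromatic carbon that is a number and not a limit. Replacing acetyl with the larger group of no common name gives an at least 1.4-fold lower number from compound 2 to compound 4 (0.15 log units; that floor lies within the scatter), so the change has a readable direction, but only a floor for its size, and that floor does not clear the usual scatter. The steps involving compound 1 cannot be read.

From the compounds shown here alone, the full size of the step stays open, as compound 2 gives > 200 uM, which is a limit and not a number. Also open, going by these compounds, is how the number would respond to a carboxylic acid or an amine on this aromatic carbon, or to oxygen in place of the sulfur in the incoming group.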